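A few compounds are considered here, and "the series" means these few. Any claim that something is new, unique, unknown or untested is made for them only; others in the source may bear on it.

Measured so far:
Compound 1, `CC(C)C[C@H](N)c1cc(C(F)(F)F)ccc1N1CCN(C(=O)[C@H]2CSC[C@@H]2c2ccc(Cl)cc2)CC1`: in an assay on HEK293 cells for displacement of a labelled ligand from Melanocortin receptor 4 (Homo sapiens) (on this read-out higher numbers stand for weaker inhibition and lower numbers for stronger inhibition), compound 1 gives 280 nM.
Compound 2, `CC(C)C[C@H](N)c1cc(C(F)(F)F)ccc1N1CCN(C(=O)C2COCC2c2ccc(Cl)cc2)CC1`: in this assay compound 2 gives 280 nM.

Compound 2 stands level with compound 1 at the digits shown, within the scatter of repeated measurements; the one measured comparison is no change at the digits printed from compound 1 to compound 2 (within the scatter). Compound 3, `CC(C)C[C@H](NC(=O)CCN(C)C)c1cc(C(F)(F)F)ccc1N1CCN(C(=O)C2COCC2c2ccc(Cl)cc2)CC1`, is not yet measured. It differs from compound 2 by (2-(dimethylamino)ethyl)carbonyl in place of hydrogen on an amine nitrogen. Within the data shown here, that single measured step concerns a different part of the shared core, the ring attached to the carbonyl carbon, so no measured step speaks directly to a change at the amine nitrogen. Resting only on compound 2 at 280 nM, the expected step of a 1.8-fold higher number from compound 2 to compound 3 (0.25 log units; within the scatter) is modest and uncertain in direction. Compound 3 is therefore estimated to give 500 nM in this assay, with a range from 100 nM to 2500 nM.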

Compound 3, inhibition constant: 71 nM
The estimate for compound 3 lay 7.0-fold (0.85 log units) above the measured number, outside the stated range (below it).
By their numbers in this assay, from the lowest: compound 3; then compounds 1 and 2 (each within the scatter of the next).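

Compared with hydrogen, the (2-(dimethylamino)ethyl)carbonyl group on the amine nitrogen gives a 3.9-fold lower number from compound 2 to compound 3 (0.60 log units; beyond the scatter) in this assay. This is the first step shown to go beyond the scatter, unlike the earlier change on the carbonyl carbon, which gave no change at the digits printed from compound 1 to compound 2 (within the scatter). It shows that the amine nitrogen need not keep its hydrogen for binding to be measured here, and that a group with 7 heavy atoms can be placed on it with a stronger result, though no measurement shown here accounts for this step.

Which part of the new group matters remains open: an acetyl group, a longer chain before the amine or a diethylamino end could help separate the carbonyl, chain and amine. From the compounds shown here alone, whether the same change gives a similar step on compound 1 also remains open.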